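From 2-Methyl-1,3-thiazol-4-yl to 1-Methyl-1H-imidazol-4-yl

The source may report more compounds than this note shows. Statements on the series, on what has been measured and on what is new or still open speak of the compounds shown alone.

Of the compounds shown here, three have so far been measured in an in vivo ADME assay on the whole organism (strain 129/SvEvBrd x C57BL/6) for pharmacokinetics, with Mus musculus as the target; on this read-out higher numbers stand for higher oral bioavailability and lower numbers for lower oral bioavailability. Compound 1 (`CC(=O)c1nc([C@@H](O)[C@H](O)[C@H](O)CO)cn1C`) gives 33.6%, and compound 2 (`CC(=O)c1nc([C@@H](O)[C@H](O)[C@H](O)CO)c(C)[nH]1`) gives 11%. Compound 3 (`Cc1nc(-c2nc([C@@H](O)[C@H](O)[C@H](O)CO)c[nH]2)cs1`) gives 23%, the second highest of the three numbers. Compound 1 lies above it and compound 2 below it, each by more than the usual scatter.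

Compound 4 (`Cn1cnc(-c2nc([C@@H](O)[C@H](O)[C@H](O)CO)c[nH]2)c1`) differs from compound 3 in one place, with 1-methyl-1H-imidazol-4-yl in place of 2-methyl-1,3-thiazol-4-yl on an aromatic carbon. That carbon belongs to a five-membered aromatic ring with 2 nitrogen and lies between two ring nitrogen atoms.

Within the data shown here, no two measured compounds differ in only one place, so the data offer no direct precedent for the size or direction of this exchange. The expectation therefore rests on compound 3 at 23%, and no change beyond the scatter is expected in this assay. The estimated step is a number 1 percentage points lower from compound 3 to compound 4 (within the scatter), with no firm direction implied. For compound 4 the expected value is 22%, with an estimated range of 8% to 40%.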

Compound 4, oral bioavailability: 3%
For compound 4 the middle estimate is 19 percentage points above the measured one; measured number outside the range, below it.
By their numbers in this assay, from the lowest: compounds 4 and 2 (each within the scatter of the next); then compound 3; then compound 1.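

Among these compounds, compound 4 supplies the first comparison in this assay between two compounds that differ in one place, with a number 20 percentage points lower from compound 3 to compound 4 (beyond the scatter) when 1-methyl-1H-imidazol-4-yl replaces 2-methyl-1,3-thiazol-4-yl, and so shows that oral bioavailability responds to the group on this aromatic carbon between two ring nitrogen atoms. The two groups have the same number of heavy atoms, hydrogen-bond donors and hydrogen-bond acceptors, and neither carries a net charge; the entering group has nitrogen where the leaving group has sulfur, so a step beyond the scatter can occur even where these counts stay the same. Nothing measured here accounts for the size of this step.

Among the compounds shown here, the single pair leaves open whether the step comes from the exchange of sulfur for nitrogen in the ring or from the different placing of the methyl group, and whether it would recur on the cores of compound 1 or compound 2. It also leaves open how oral bioavailability would respond on this carbon to a group of another kind, such as an amine, a carboxylic acid or a longer alkyl chain.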